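A few compounds are considered here, and "the series" means these few. Any claim that something is new, unique, unknown or untested is made for them only; others in the source may bear on it.

Measured in an assay on brain for displacement of a labelled ligand from Sigma non-opioid intracellular receptor 1 (Rattus norvegicus); a higher number here means a weaker inhibitor, a lower number a stronger inhibitor:

compound 1 `CN(Cc1ccccc1)[C@H]1C2C3CC4C2C(=O)C2C4C3C21` gives 568 nM
compound 2 `CN(Cc1cccnc1)[C@H]1C2C3CC4C2C(=O)C2C4C3C21` gives 734 nM
compound 3 `CN(Cc1ccccc1)[C@H]1C2C3CC4C5C3CC2C5C41` gives 770 nM

Compound 1 and compound 2 share one core and differ in a single place: pyridin-3-yl in place of phenyl on a saturated chain carbon bound to an amine nitrogen. That change made a 1.3-fold higher number from compound 1 to compound 2 (0.11 log units; within the scatter), so the two numbers are indistinguishable within the usual scatter. Compound 3 is built on another core; the difference between the two cores is not broken down here. Compound 4 `CN(Cc1cccnc1)[C@H]1C2C3CC4C5C3CC2C5C41` is not yet measured and carries the same change on the core of compound 3: pyridin-3-yl in place of phenyl on a saturated chain carbon bound to an amine nitrogen. The step expected from compound 3 to compound 4 in this assay is a 1.3-fold higher number from compound 3 to compound 4 (0.11 log units; within the scatter), a small one like the earlier step, and this rests on the result a 1.3-fold higher number from compound 1 to compound 2 (0.11 log units; within the scatter). Compound 4 is therefore estimated at 1000 nM, with the number expected to fall between 500 nM and 2000 nM.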

Compound 4, inhibition constant: 970 nM
Beside the measured number, compound 4's estimate is 1.0-fold (0.01 log units) above it; low and high end bracket the measured number.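

In this assay, the same swap on the core of compound 3 gives a 1.3-fold higher number from compound 3 to compound 4 (0.10 log units; within the scatter), so on this core too the pyridin-3-yl and phenyl compounds cannot be told apart. Set side by side, the two steps agree: the same change on two cores in this assay, a 1.3-fold higher number (0.11 log units; within the scatter) from compound 1 to compound 2 and a 1.3-fold higher number (0.10 log units; within the scatter) from compound 3 to compound 4, 1.0-fold (0.01 log units) apart, within the scatter of two such steps. The change therefore transfers between these two cores in the sense that it stays small on both, but neither step rises above the scatter, so this shows no real effect of the change and says nothing about any other core.

The compounds shown leave open whether a carboxylic acid or a longer chain in place of phenyl would move the number, and whether such a step would also carry from one core to the other.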